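The compounds below may be only part of what the source reports. "The series", "measured", "known", "first", "only" and "open" are said of these compounds alone.

Compound 1 `Cc1ccnc(/C(N)=N/NC(=S)N2CCSCC2)c1` gives 60% in a functional assay on A-431 cells (Homo sapiens) for cytotoxicity, read by MTT assay, with a stated time of 72 h, tested at 10 uM; on this read-out lower numbers stand for less inhibition of growth and higher numbers for more inhibition of growth at the one concentration tested.
Compound 2 `N/C(=N\NC(=S)N1CCSCC1)c1ccccn1` gives 61.4%.
Compound 3 `Cc1cccc(/C(N)=N/NC(=S)N2CCCCC2)n1` gives 47.8%.

Among the three measured compounds, compound 3 stands lowest on the numbers shown. Its nearest neighbour is compound 1, whose number lies above it by a gap beyond the scatter, and the furthest is compound 2, whose number lies further above it, also beyond the scatter.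

Compound 4 `Cc1cccc(/C(N)=N/NC(=S)N2CCCC2)n1` differs from compound 3 in one place: pyrrolidin-1-yl in place of piperidin-1-yl on a thiocarbonyl carbon. The only measured step among these compounds, a number 1.4 percentage points higher from compound 1 to compound 2 (within the scatter), concerns hydrogen in place of methyl on an aromatic carbon and stays within the scatter; it does not touch the ring on the thiocarbonyl carbon, so no measured step bears directly on the change from compound 3 to compound 4. With nothing to point either way, compound 4 is expected to stay close to compound 3, with a step of a number 0.2 percentage points higher from compound 3 to compound 4 (within the scatter) that is not expected to exceed the scatter. Compound 4 is therefore estimated at 48%, within a range from 35% to 61%.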

Compound 4, percent growth inhibition at one concentration: 67.6%
Estimate against measurement, compound 4: 19.6 percentage points below; the measured number lies above the stated range.
By their numbers in this assay, from the lowest: compound 3; then compounds 1, 2 and 4 (each within the scatter of the next).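

The ring on the thiocarbonyl carbon is a place where this assay responds: pyrrolidin-1-yl in place of piperidin-1-yl gives a number 19.8 percentage points higher from compound 3 to compound 4 (beyond the scatter), a step beyond the scatter. Within the data shown here, the only earlier step, a number 1.4 percentage points higher from compound 1 to compound 2 (within the scatter), concerned hydrogen in place of methyl on an aromatic carbon and left this ring untouched, so this is the first sign that a five-membered ring and a six-membered ring on this carbon are not interchangeable here. Nothing measured here explains why the two rings differ.

On these data alone, it remains open whether azetidin-1-yl or an open-chain group such as dimethylamino on the thiocarbonyl carbon would follow the same direction. As far as these compounds go, it is also open whether pyrrolidin-1-yl would give a similar step on the core of compound 2.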